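The source may report more compounds than this note shows. Statements on the series, on what has been measured and on what is new or still open speak of the compounds shown alone.

For the measured compounds named here, in a functional assay on MC-38 cells (Mus musculus) for antiproliferative activity, read by CCK-8 assay, with a stated time of 48 h (a higher number here means a weaker inhibitor, a lower number a stronger inhibitor), compound 3 (`COc1ccc(/C=C\c2cc(OC)c(OC)c(OC)c2)cc1OCc1ccc(CNCCNC(C)=O)cc1`) gives 1800 nM and is the only compound so far with a number. Compound 1 (`COc1ccc(/C=C\c2cc(OC)c(OC)c(OC)c2)cc1OCc1ccc(CN2CCCC[C@@H]2C(=O)O)cc1`) reads > 10000 nM which is a limit of the assay, not a number. Compound 2 (`COc1ccc(/C=C\c2cc(OC)c(OC)c(OC)c2)cc1OCc1ccc(CN2CC(C(=O)O)C2)cc1`) reads > 10000 nM which is likewise a limit.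

Compound 4 (`COc1ccc(/C=C\c2cc(OC)c(OC)c(OC)c2)cc1OCc1ccc(CN2CC[C@@H](C(=O)O)C2)cc1`) keeps the shared core and carries 3-carboxypyrrolidin-1-yl in place of (2-acetamidoethyl)amino on a saturated chain carbon bound to an aromatic carbon.

Going by the values given here, two measured steps bear on this change, and both run in the opposite direction: an at least 5.5-fold lower number from compound 1 to compound 3 (0.74 log units; beyond the scatter) and an at least 5.5-fold lower number from compound 2 to compound 3 (0.74 log units; beyond the scatter). Each replaces a carboxy-bearing ring group with the same (2-acetamidoethyl)amino group found in compound 3. Both sizes are bounded by limits, so neither gives a full measure. The remaining step, a step that the two limits leave unreadable from compound 1 to compound 2, offers no size to work from. Compound 4 also bears a carboxy-bearing ring group, so a reversal of the two measured steps is the closest guide.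

The expected change is a 6.7-fold higher number from compound 3 to compound 4 (0.82 log units; beyond the scatter) in this assay toward a higher number and a weaker inhibitor. Compound 4 is estimated at 12000 nM (expected range 4000 nM to 40000 nM) and may well return only a limit.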

Compound 4, half-maximal inhibitory concentration: 6300 nM
The estimate for compound 4 lay 1.9-fold (0.28 log units) above the measured number; measured number inside the range.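

In this assay, for the compounds shown here, compound 4 gives 6300 nM and is the only one of the carboxy-bearing ring compounds to give a number. So a carboxy-bearing ring on this saturated chain carbon does not always leave a compound without a number. Going by these compounds alone, the loss on leaving (2-acetamidoethyl)amino for 3-carboxypyrrolidin-1-yl now has a measured size (a 3.5-fold higher number from compound 3 to compound 4 (0.54 log units; beyond the scatter)), where the earlier steps of this kind gave only floors. Against the other two ring compounds only floors can be read (an at least 1.5-fold lower number from compound 2 to compound 4 (0.20 log units; that floor lies within the scatter); an at least 1.5-fold lower number from compound 1 to compound 4 (0.20 log units; that floor lies within the scatter)), and they remain floors, with no ordering of the three rings to be drawn, because compound 1 and compound 2 both sit at a limit: the limit of > 10000 nM in this assay, at which 2 of the 4 values shown sit.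

The compounds shown leave open whether the step from compound 3 follows from the carboxylic acid or from the ring, which plain pyrrolidin-1-yl or the methyl ester of 3-carboxypyrrolidin-1-yl would separate, and what the opposite configuration at the stereocentre would give. Also open, from the compounds shown here alone, is how a primary amine, or a chain longer than (2-acetamidoethyl)amino, would read at this place.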